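Demethylation on compound 1 and its expected cytotoxicity

The source may report more compounds than this note shows. Statements on the series, on what has been measured and on what is new or still open speak of the compounds shown alone.

Compound 1 `COc1ccc(C2=C(c3cc(OC)c(OC)c(OC)c3)C(=O)CC2O[SiH2]C(C)(C)C)cc1OC` is one of three measured members of the series. In an ADME assay on HEK293 cells (Homo sapiens) for cytotoxicity, read by MTT assay, with a stated time of 72 h (a higher number here means a weaker inhibitor, a lower number a stronger inhibitor), compound 1 gives > 100 ug/mL, which is a limit of the assay and not a number. Compound 2 `COc1cc(C2=C(c3ccc(OCC(=O)O)cc3)C(O)CC2=O)cc(OC)c1OC` in this assay gives > 100 ug/mL, again only a limit. Compound 3 `CCOC(=O)COc1ccc(C2=C(c3cc(OC)c(OC)c(OC)c3)C(=O)CC2O)cc1` in this assay gives > 100 ug/mL, also a limit. Within the data shown here, the only single-point step among them, a step that the two limits leave unreadable from compound 2 to compound 3, has no readable size. Among the measured compounds shown here, the whole evidence is the limit of > 100 ug/mL in this assay, at which 3 of the 3 values shown sit, so compound 1 stands at that limit together with the others, and no step has a size that can be read.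

Compound 4 `COc1ccc(C2=C(c3cc(OC)c(OC)c(OC)c3)C(=O)CC2O[SiH2]C(C)(C)C)cc1O` differs from compound 1 by hydrogen in place of methyl on an oxygen on an aromatic ring. For the measured compounds named here, no measured step covers this change, and the one step that exists is unreadable, so it offers no size to carry over. The expected step from compound 1 to compound 4 in this assay, a step that the limit leaves unreadable from compound 1 to compound 4, is none beyond the scatter. Compound 4 is estimated at 150 ug/mL in this assay, with a range from 70 ug/mL to 400 ug/mL, most likely reported again only as a limit.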

Compound 4, half-maximal inhibitory concentration: 42 ug/mL
For compound 4 the middle estimate is 3.6-fold (0.55 log units) above the measured one; measured number outside the range, below it.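

In this assay, the change from methoxy to hydroxy, which turns 3,4-dimethoxyphenyl into 3-hydroxy-4-methoxyphenyl, gives an at least 2.3-fold lower number from compound 1 to compound 4 (0.37 log units; beyond the scatter). Among these compounds, this is the first step with a readable size, and it shows that this single place on the aromatic ring can bring a compound off the limit, where the rest of the series stays: the limit of > 100 ug/mL in this assay, at which 3 of the 4 values shown sit. The size is only a minimum, as the step starts from a limit, and the other step in the series cannot be read.

Going by these compounds, it remains open whether the free hydroxy is what matters at this place, or whether an amine or an ethoxy group there would give a comparable step. Also open, on these data alone, is whether the same change on the other aromatic ring would lower the number in the same way.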